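Two Amine Swaps on a Dicyano Core: Predicting Compound 4

This account rests on a few compounds, and the source may have more. Where it says the series, first, only, none or still open, it means among the compounds named here.

Compound 1 `CCN(CC)CCn1c(N)c(-c2nc3ccccc3[nH]2)c2nc(C#N)c(C#N)nc21` gives 1880 nM in a functional assay on HL-60 cells (Homo sapiens) for antiproliferative activity, read by MTT assay, with a stated time of 48 h; a lower number here means a stronger inhibitor, a higher number a weaker inhibitor.
Compound 2 `CN(C)CCCn1c(N)c(-c2nc3ccccc3[nH]2)c2nc(C#N)c(C#N)nc21` gives 870 nM in this assay.
Compound 3 `CCN(CC)CCCn1c(N)c(-c2nc3cc(Cl)ccc3[nH]2)c2nc(C#N)c(C#N)nc21` gives 3470 nM in this assay.

For the measured compounds named here, the one change that is tracked between measured compounds is the step from compound 1 to compound 2: (dimethylamino)methyl in place of diethylamino on a saturated chain carbon, two bonds along the chain from an aromatic nitrogen. In this assay it reads a 2.2-fold lower number from compound 1 to compound 2 (0.33 log units; beyond the scatter).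

Compound 3 carries a different core from compound 1; how the two cores differ is not broken down here. Compound 3 stands highest of the three measured numbers, with compound 1 within the scatter of it and compound 2 beyond it.

Compound 4 `CN(C)CCCCn1c(N)c(-c2nc3cc(Cl)ccc3[nH]2)c2nc(C#N)c(C#N)nc21` has not yet been measured. It differs from compound 3 by (dimethylamino)methyl in place of diethylamino on a saturated chain carbon, three bonds along the chain from an aromatic nitrogen. Going by the values given here, this is the same kind of change as the one from compound 1 to compound 2, but not the same: there the change sat two bonds along the chain from the aromatic nitrogen, here it sits three bonds along.

Because a 2.2-fold lower number from compound 1 to compound 2 (0.33 log units; beyond the scatter) was measured on the core of compound 1, a step of about the same direction is expected on the core of compound 3, tempered by the longer chain and the different core. The step from compound 3 to compound 4 is expected to be a 1.8-fold lower number from compound 3 to compound 4 (0.26 log units; within the scatter). Compound 4 is therefore estimated at 1900 nM in this assay, with a plausible range from 900 nM to 3800 nM.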

Compound 4, half-maximal inhibitory concentration: 1480 nM
Compound 4: middle estimate off by 1.3-fold (0.11 log units), on the high side; the range from low to high includes it.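

In this assay the new step reads a 2.3-fold lower number from compound 3 to compound 4 (0.37 log units; beyond the scatter), and it runs the same way as the step measured earlier on the core of compound 1, with a size that matches it: the same change on two cores in this assay, a 2.2-fold lower number (0.33 log units; beyond the scatter) from compound 1 to compound 2 and a 2.3-fold lower number (0.37 log units; beyond the scatter) from compound 3 to compound 4, 1.1-fold (0.04 log units) apart, within the scatter of two such steps. So in this series the exchange of a diethylamino end for a dimethylamino end one carbon further out carried from one core to the other without visible loss, on both the 2-(diethylamino)ethyl to 3-(dimethylamino)propyl pair and the 3-(diethylamino)propyl to 4-(dimethylamino)butyl pair. This rests on two pairs only, however, and it does not show that the step would hold on any further core or at any other chain length, nor does it say why the step occurs.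

Each pair changes the amine and the chain length together, so the compounds shown leave open how much of the step belongs to the smaller amine and how much to the longer chain. They also leave open whether the trend continues with a chain longer than 4-(dimethylamino)butyl, and what a cyclic amine such as piperidine would do in place of dimethylamino.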